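This account rests on a few compounds, and the source may have more. Where it says the series, first, only, none or still open, it means among the compounds named here.

In an assay for inhibition of 15-hydroxyprostaglandin dehydrogenase [NAD(+)] (Homo sapiens), read by fluorescence, with a stated time of 15 min, in the presence of a further agent that is not named here (a lower number here means a stronger inhibitor, a higher number a weaker inhibitor), compound 1, `CCCC[S+]([O-])c1nc2ccc(-c3cccs3)nc2[nH]1`, reports > 7500 nM, which is the limit of > 7500 nM in this assay, at which 1 of the 3 values shown sits, rather than a number. Compound 2, `CCCC[S+]([O-])c1sc2nc(-c3ncco3)cc(-c3ccccc3)c2c1N`, gives 1.4 nM. Compound 3, `CCCC[S+]([O-])c1sc2nc(-c3nccs3)cc(-c3ccc(C(=O)N(C)C)cc3)c2c1N`, gives 5.9 nM, the higher of the two numbers shown, and its gap from compound 2 lies beyond the usual scatter. Compound 4, `CCCC[S+]([O-])c1sc2nc(-c3nccs3)cc(-c3ccc(CO)cc3)c2c1N`, has not yet been measured in this assay. It differs from compound 3 in one place: hydroxymethyl in place of dimethylcarbamoyl on an aromatic carbon, set para to a large group. Among the compounds with values here, no measured pair shows this change, so its effect is open. Because compound 3 gives 5.9 nM, compound 4 is expected near 6 nM, with a range from 2 nM to 20 nM. The step of a 1.0-fold higher number from compound 3 to compound 4 (0.01 log units; within the scatter) is thus expected to stay within the scatter.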

Compound 4, half-maximal inhibitory concentration: 2.5 nM
Compound 4: middle estimate off by 2.4-fold (0.38 log units), on the high side; the measured number falls inside the stated range.
By their numbers in this assay, from the lowest: compounds 2 and 4 (each within the scatter of the next); then compound 3. At a limit, above all of these: compound 1.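

At this aromatic carbon, para to a large group, hydroxymethyl can stand in place of dimethylcarbamoyl without loss in this assay, with a 2.4-fold lower number from compound 3 to compound 4 (0.37 log units; beyond the scatter). The dimethylcarbamoyl group is therefore not required here for a low number, and a substituent with fewer heavy atoms and a hydrogen-bond donor also reads well. Nothing measured here gives a reason for this step.

The compounds shown leave open whether the hydroxyl matters itself or the step reflects only the loss of dimethylcarbamoyl. On these data alone, how a methoxymethyl group, an aminomethyl group, a carboxylic acid or a longer hydroxyalkyl chain would read at this carbon also remains open.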